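Replacing the 4-methoxyphenyl group of compound 1

The compounds below may be only part of what the source reports. "The series", "measured", "known", "first", "only" and "open" are said of these compounds alone.

Among the measured compounds shown here, in a functional assay on FaDu cells (Homo sapiens) for cytotoxicity, read by MTT assay, with a stated time of 72 h (on this read-out lower numbers stand for higher toxicity in this test and higher numbers for lower toxicity in this test), compound 1 `COc1ccc(NC(=O)C(=O)c2cn(C(C)C)c3ccccc23)cc1` gives 181 nM, the higher of the two numbers so far, and compound 2 `COCCn1cc(C(=O)C(=O)Nc2ccc(OC)cc2)c2ccccc21` gives 59 nM. Compound 3 `COc1cc(NC(=O)C(=O)c2cn(C(C)C)c3ccccc23)ccn1` has 2-methoxypyridin-4-yl in place of 4-methoxyphenyl on an amide-type nitrogen and retains the isopropyl group of compound 1: 2-methoxypyridin-4-yl in place of 4-methoxyphenyl on an amide-type nitrogen.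

For the measured compounds named here, the only measured step, a 3.1-fold lower number from compound 1 to compound 2 (0.49 log units; beyond the scatter), is modest but beyond the scatter. It replaces isopropyl with 2-methoxyethyl on an aromatic nitrogen, so it does not test the group now changing. Going by the values given here, no measured pair varies the group on the amide-type nitrogen, which leaves the direction open. No step beyond the scatter is expected in this assay, though with wide uncertainty. The estimated change is a 1.1-fold higher number from compound 1 to compound 3 (0.04 log units; within the scatter). For compound 3 the estimated value is 200 nM, with an expected range of 60 nM to 700 nM.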

Compound 3, concentration lethal to 50% of the cells: 1750 nM
Beside the measured number, compound 3's estimate is 8.8-fold (0.94 log units) below it, outside the stated range (above it).
By their numbers in this assay, from the lowest: compound 2; then compound 1; then compound 3.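

In this assay the group on the amide-type nitrogen is not a silent position: 2-methoxypyridin-4-yl in place of 4-methoxyphenyl gives a 9.7-fold higher number from compound 1 to compound 3 (0.99 log units; beyond the scatter). Both groups have 8 heavy atoms, and the entering one has a ring nitrogen in place of a ring carbon and 2 hydrogen-bond acceptors against 1, so a change of this small kind at this position moves the number beyond the scatter. The two single-place changes on compound 1 now run in opposite directions, as the earlier 3.1-fold lower number from compound 1 to compound 2 (0.49 log units; beyond the scatter) goes the other way, and no data on hand explain the rise seen with the pyridine-containing group.

Open, on these data alone, is whether this step holds with 2-methoxyethyl in place of isopropyl on the aromatic nitrogen. Also open, as far as these compounds go, is how an amino group or a carboxylic acid on this ring, or a longer chain such as ethoxy in place of methoxy, would read in this assay.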